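Swapping 4-methylphenyl for 3-methoxyphenyl on a shared core

A few compounds are considered here, and "the series" means these few. Any claim that something is new, unique, unknown or untested is made for them only; others in the source may bear on it.

Compound 1 `Cc1ccc(/C=C2\SC(=S)N(NS(=O)(=O)c3ccccc3)C2=O)cc1` gives > 50000 nM
Compound 2 `O=S(=O)(NN1C(=S)S/C(=C\c2ccc(Cl)c(Cl)c2)C1O)c1ccc(Cl)cc1` gives > 50000 nM

In a functional assay on ECV-304 cells (Homo sapiens) for cytotoxicity (on this read-out lower numbers stand for stronger inhibition and higher numbers for weaker inhibition), compound 1 stands at > 50000 nM as a limit, not a number. Compound 2 at > 50000 nM is also only a limit. For the measured compounds named here, compound 3 `COc1cccc(/C=C2\SC(=S)N(NS(=O)(=O)c3ccccc3)C2=O)c1` keeps the core of compound 1 but takes 3-methoxyphenyl in place of 4-methylphenyl on a double-bonded chain carbon bound to a double-bonded ring carbon as its one change. Going by the values given here, no measured step is available to size this change. The step of a number no higher from compound 1 to compound 3 (the limit leaves the size open) is expected to stay within the scatter of this assay and to have no clear direction. Compound 3 is estimated at 50000 nM with an expected range from 20000 nM to 100000 nM around it.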

Compound 3, half-maximal inhibitory concentration: > 50000 nM
Compound 3 ended at the assay's limit; the forecaster's own chance of this, stated with the estimate: 70%; the middle value sits exactly at the limit.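

No step can be read from compound 1 to compound 3, as both values are only limits: the limit of > 50000 nM in this assay, at which 3 of the 3 values shown sit. The compounds shown leave open whether 3-methoxyphenyl in place of 4-methylphenyl changes the read-out at all.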